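Diazepane in place of the open diamine: cytotoxicity notes

The compounds below may be only part of what the source reports. "The series", "measured", "known", "first", "only" and "open" are said of these compounds alone.

Measured so far:
compound 1, `CN(C)CCN(C)c1ccc(C#N)c(CN2CCN(C(c3ccc(F)cc3)c3ccc(F)cc3)CC2)c1`, 7810 nM
compound 2, `CN1CCCN(c2ccc(C#N)c(CN3CCN(C(c4ccc(F)cc4)c4ccc(F)cc4)CC3)c2)CC1`, 6240 nM
compound 3, `CN(C)CCN(C)c1ccc(C#N)c(CN2CCN([C@@H](c3ccccc3)c3ccc(Cl)cc3)CC2)c1`, 8780 nM

All three were read in a toxicity assay on Huh-7.5 cells (Homo sapiens) for cytotoxicity, read by MTT assay, with a stated time of 96 h; on this read-out lower numbers stand for higher toxicity in this test and higher numbers for lower toxicity in this test. Compound 2 differs from compound 1 by 4-methyl-1,4-diazepan-1-yl in place of (2-(dimethylamino)ethyl)(methyl)amino on an aromatic carbon, and the step of a 1.3-fold lower number from compound 1 to compound 2 (0.10 log units; within the scatter). Compound 3 shares the aryl amine of compound 1 but the difference between the two cores is not broken down here; the values of compound 1 and compound 3 lie within the scatter of each other. Compound 4, `CN1CCCN(c2ccc(C#N)c(CN3CCN([C@@H](c4ccccc4)c4ccc(Cl)cc4)CC3)c2)CC1`, is not yet measured; it differs from compound 3 by 4-methyl-1,4-diazepan-1-yl in place of (2-(dimethylamino)ethyl)(methyl)amino on an aromatic carbon, the same change at the same place as from compound 1 to compound 2. In this assay the step of a 1.3-fold lower number from compound 3 to compound 4 (0.10 log units; within the scatter) is expected for compound 4, a step resting on a 1.3-fold lower number from compound 1 to compound 2 (0.10 log units; within the scatter), which showed no movement beyond the scatter. For compound 4 the estimate in this assay is 7000 nM, with a range from 3500 nM to 14000 nM.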

Compound 4, half-maximal cytotoxic concentration: > 20000 nM
Compound 4 gave a limit, no number (the forecaster's own chance of this, stated with the estimate: 10%); middle value at least 2.8-fold (0.45 log units) from the limit.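

In this assay, 4-methyl-1,4-diazepan-1-yl in place of (2-(dimethylamino)ethyl)(methyl)amino gives an at least 2.2-fold higher number from compound 3 to compound 4 (0.35 log units; beyond the scatter), so the change does not carry over unchanged between these two cores: the same change on two cores in this assay, a 1.3-fold lower number (0.10 log units; within the scatter) from compound 1 to compound 2 and an at least 2.2-fold higher number (0.35 log units; beyond the scatter) from compound 3 to compound 4, at least 2.8-fold (0.45 log units) apart, beyond the scatter of two such steps

Compound 4 gives > 20000 nM, which is a limit and not a number, so the full size of this step remains unknown: the limit of > 20000 nM in this assay, at which 1 of the 4 values shown sits.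

This pair of cores shows that the outcome of the change can differ with the core, but it does not show which core feature is responsible or how the change would read on any other core.

Open, on these data alone, is how a primary amine or a longer diamine chain on the same aromatic carbon would read in this assay on either core. Also open, as far as these compounds go, is whether the step from the open diamine to the diazepane stays the same when the chlorine on the core of compound 3 gives way to fluorine.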